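A few compounds are considered here, and "the series" means these few. Any claim that something is new, unique, unknown or untested is made for them only; others in the source may bear on it.

In a functional assay on HepG2 cells (Homo sapiens) for antiproliferative activity, read by sulforhodamine B assay, with a stated time of 72 h (on this read-out higher numbers stand for weaker inhibition and lower numbers for stronger inhibition), three compounds sharing one core have been measured. Within the data shown here, compound 1 (`CC(C)C[C@@H](NC(=O)OC(C)(C)C)C(=O)Nc1ccc2ncnc(Nc3ccc(F)c(Cl)c3)c2c1`) gives 13800 nM, the only true number in the set. Compound 2 (`CC(C)(C)OC(=O)NCC(=O)Nc1ccc2ncnc(Nc3cccc(C(F)(F)F)c3)c2c1`) is reported only as a limit of the assay, > 50000 nM. Compound 3 (`C[C@@H](NC(=O)OC(C)(C)C)C(=O)Nc1ccc2ncnc(Nc3cccc(C(F)(F)F)c3)c2c1`) is likewise reported only as a limit, > 50000 nM. Compound 3 therefore has no number of its own and stands with compound 2 at the limit of > 50000 nM in this assay, at which 2 of the 3 values shown sit.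

Compound 4 (`CC(C)C[C@@H](NC(=O)OC(C)(C)C)C(=O)Nc1ccc2ncnc(Nc3cccc(C(F)(F)F)c3)c2c1`) differs from compound 3 by isopropyl in place of hydrogen on a saturated chain carbon, two bonds along the chain from an amide-type nitrogen and a carbonyl carbon. The change is isopropyl in place of hydrogen on a saturated chain carbon, two bonds along the chain from an amide-type nitrogen and a carbonyl carbon. Cut one bond further out, it reads methyl to isobutyl. Among the measured compounds shown here, the one measured step at this part of the chain is a step that the two limits leave unreadable from compound 2 to compound 3, so it offers no size to carry forward. For the measured compounds named here, the only guide is compound 1, which also carries the isobutyl and gives 13800 nM. On that value, a shift towards stronger inhibition is expected, though a modest one that may not clear the limit. The expected change is an at least 1.7-fold lower number from compound 3 to compound 4 (0.25 log units; that floor lies within the scatter). For compound 4 the estimated value is 28000 nM, with an expected range of 12000 nM to 50000 nM.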

Compound 4, half-maximal inhibitory concentration: > 50000 nM
Compound 4 ended at the assay's limit; the forecaster's own chance of this, stated with the estimate: 45%; at least 1.7-fold (0.25 log units) between middle value and limit.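

Isobutyl at this chain carbon does not bring compound 4 to a true number in this assay: compound 4 gives > 50000 nM, which is a limit of the assay. The steps that join compound 4 to compound 2 and to compound 3 therefore cannot be read, and the new information lies in the comparison with compound 1, where the isobutyl is held fixed and 3-(trifluoromethyl)phenyl stands in place of 3-chloro-4-fluorophenyl on a nitrogen on an aromatic ring, giving an at least 3.6-fold higher number from compound 1 to compound 4 (0.55 log units; beyond the scatter). Isobutyl alone is thus not enough for a measurable value in this pair, which depends on the group on that nitrogen, and the series now stands as follows: the limit of > 50000 nM in this assay, at which 3 of the 4 values shown sit.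

With 3-(trifluoromethyl)phenyl on that nitrogen, any effect of the chain group remains hidden behind the limit, and the compounds shown do not tell whether the isobutyl contributes to the value of compound 1. Also open, on these data alone, is how a 3-chloro-4-fluorophenyl compound would respond to hydrogen or methyl at the chain carbon, or to a chain group carrying an amine or a carboxylic acid.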